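Tellurium in Place of Selenium on a Cytotoxic Scaffold

The compounds below may be only part of what the source reports. "The series", "measured", "known", "first", "only" and "open" are said of these compounds alone.

Two measured compounds share one core. Compound 1 `COc1ccc(N(CC(=O)NCCC[Se]c2ccccc2)C(=O)CNC(=O)OC(C)(C)C)cc1` and compound 2 `COc1ccc(N(CC(=O)NCCC[Se]c2ccccc2)C(=O)/C=C/c2ccccc2)cc1` were both tested in a functional assay on MCF7 cells (Homo sapiens) for cytotoxicity, read by MTT assay, with a stated time of 24 h; on this read-out higher numbers stand for weaker inhibition and lower numbers for stronger inhibition. In this assay compound 1 gives only a limit, >= 100000 nM. In this assay compound 2 likewise gives only a limit, >= 100000 nM. Going by the values given here, the single measured step, a step that the two limits leave unreadable from compound 1 to compound 2, cannot be sized because both values sit at the limit of >= 100000 nM in this assay, at which 2 of the 2 values shown sit. Compound 2 therefore stands at the edge of what this assay reports, and nothing in the numbers shown places it above or below compound 1.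

Compound 3 `COc1ccc(N(CC(=O)NCCC[Te]c2ccccc2)C(=O)/C=C/c2ccccc2)cc1` differs from compound 2 by a group of 7 heavy atoms (6 carbon, 1 tellurium; one six-membered aromatic ring of carbon only) in place of a group of 7 heavy atoms (6 carbon, 1 selenium; one six-membered aromatic ring of carbon only), on a saturated chain carbon, three bonds along the chain from an amide-type nitrogen. No measured pair differs at this place, so no measured step bears on this change, and the one step shown is itself unreadable. The expected step of a number no higher from compound 2 to compound 3 (the limit leaves the size open) is thus no step beyond the scatter, with compound 3 expected to remain at the limit. For compound 3 the estimated value in this assay is 100000 nM. The expected range for compound 3 runs from 20000 nM to 300000 nM.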

Compound 3, half-maximal inhibitory concentration: 2000 nM
Beside the measured number, compound 3's estimate is 50-fold (1.70 log units) above it; the whole stated range lies above it.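

Going by these compounds alone, the only step among the earlier compounds cannot be read, so they gave no sign that any part of this structure affects the number in this assay. Placing the tellurium-bearing group where the selenium-bearing group stood, on a saturated chain carbon, three bonds along the chain from an amide-type nitrogen, gives an at least 50-fold lower number from compound 2 to compound 3 (1.69 log units; beyond the scatter), so in this pair a single changed atom, in groups otherwise matched in carbon count and ring, separates a compound at the limit from one with a measurable value. That step gives only the smallest size the change can have, because compound 2 sits at a limit: the limit of >= 100000 nM in this assay, at which 2 of the 3 values shown sit.

This one pair cannot say whether tellurium would have the same effect with the ((tert-butoxycarbonyl)amino)methyl group of compound 1 on the carbonyl carbon, as 2-phenylethenyl is the only partner shown for it. The compounds shown also leave open how a sulfur atom at this place, or a longer chain carrying the tellurium, would read in this assay.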